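Ring size at the amino-bearing side chain

The source may hold more compounds than are shown below. What is called first, only, known or untested is meant among the compounds shown, and "the series" means these compounds.

Compound 1 `COc1cccc(-c2c(C)n(Cc3c(F)cccc3F)c(=O)n(C[C@@H](N)CC(C)C)c2=O)c1F` is the reference point of the series; in an assay on HEK293 cells for binding affinity to Gonadotropin-releasing hormone receptor (Homo sapiens), read by radioligand binding (a lower number here means a stronger inhibitor, a higher number a weaker inhibitor), compound 1 gives 39 nM. Compound 2 `COc1cccc(-c2c(C)n(Cc3c(F)cccc3F)c(=O)n(C[C@H](C)NCc3ccccc3)c2=O)c1F` gives 51 nM, and compound 3 `COc1cccc(-c2c(C)n(Cc3c(F)cccc3F)c(=O)n(C[C@H](N)C3CCCC3)c2=O)c1F` gives 10 nM. Compound 3 stands lowest of the three numbers: the step of a 3.9-fold lower number from compound 1 to compound 3 (0.59 log units; beyond the scatter) and the step of a 5.1-fold lower number from compound 2 to compound 3 (0.71 log units; beyond the scatter) both lie beyond the scatter, whereas a 1.3-fold higher number from compound 1 to compound 2 (0.12 log units; within the scatter) does not.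

Compound 4 `COc1cccc(-c2c(C)n(Cc3c(F)cccc3F)c(=O)n(C[C@@H](N)C3CCCCC3)c2=O)c1F` differs from compound 3 in one place: amino(cyclohexyl)methyl in place of amino(cyclopentyl)methyl on a saturated chain carbon bound to an aromatic nitrogen. Among the measured compounds shown here, no measured step exchanges one saturated ring for another, so nothing bears on this change directly. The closest guide is a 3.9-fold lower number from compound 1 to compound 3 (0.59 log units; beyond the scatter), where a branched open chain carrying the amino group was replaced by a ring carrying it, with a modest gain. Moving from the five-membered to the six-membered ring keeps the amino group on the saturated chain carbon bound to an aromatic nitrogen and is a smaller change in kind than any step measured here. The expectation for compound 4 is therefore a number close to that of compound 3, with the step of a 1.1-fold higher number from compound 3 to compound 4 (0.04 log units; within the scatter) expected to stay within the scatter. Compound 4 is estimated at 11 nM in this assay, with a range from 4 nM to 28 nM.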

Compound 4, inhibition constant: 46 nM
The estimate for compound 4 lay 4.2-fold (0.62 log units) below the measured number, and the stated range ends below it.
By their numbers in this assay, from the lowest: compound 3; then compounds 1, 4 and 2 (each within the scatter of the next).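

In this assay, the two saturated rings on this side chain are not interchangeable: a 4.6-fold higher number from compound 3 to compound 4 (0.66 log units; beyond the scatter) places amino(cyclohexyl)methyl away from the number held by amino(cyclopentyl)methyl. A ring as such therefore does not bring the gain, since a 1.2-fold higher number from compound 1 to compound 4 (0.07 log units; within the scatter) and a 1.1-fold lower number from compound 2 to compound 4 (0.04 log units; within the scatter) both stay within the scatter, and among the compounds shown only compound 3 stands apart from the other three. No supporting data bear on the origin of the step from the cyclopentyl to the cyclohexyl compound.

The defined stereocentre is drawn with opposite arrangement in compound 3 and compound 4, so ring size and arrangement change together in this step, and the share of each remains unresolved until the amino(cyclopentyl)methyl and amino(cyclohexyl)methyl groups can be compared with the same arrangement. It also remains open how far the trend extends in ring size or ring type, as cyclobutyl, cycloheptyl and phenyl groups carrying the same amino-substituted carbon are not among the compounds shown.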